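Extending the urea of compound 3 with a methylpiperazine chain

A few compounds are considered here, and "the series" means these few. Any claim that something is new, unique, unknown or untested is made for them only; others in the source may bear on it.

Compound 3 `CNC(=O)Nc1nc2ccc(-c3cnc(OC)c(NS(=O)(=O)c4ccc(F)cc4)c3)cc2s1` gives 870 nM in a functional assay on HCT-116 cells (Homo sapiens) for antiproliferative activity, read by MTT assay, with a stated time of 72 h (a higher number here means a weaker inhibitor, a lower number a stronger inhibitor), and stands second highest of the three numbers measured. Its nearest neighbour is compound 2 `COc1ncc(-c2ccc3nc(NC4CC4)sc3c2)cc1NS(=O)(=O)c1ccc(F)cc1`, which gives 1560 nM; the step of a 1.8-fold lower number from compound 2 to compound 3 (0.25 log units; within the scatter) is within the scatter. The furthest is compound 1 `COc1ncc(-c2ccc3nc(NC(=O)NCCN4CCCC4)sc3c2)cc1NS(=O)(=O)c1ccc(F)cc1`, which gives 310 nM; the step of a 2.8-fold higher number from compound 1 to compound 3 (0.45 log units; beyond the scatter) goes beyond the scatter, as does a 5.0-fold higher number from compound 1 to compound 2 (0.70 log units; beyond the scatter).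

Compound 4 `COc1ncc(-c2ccc3nc(NC(=O)NCCN4CCN(C)CC4)sc3c2)cc1NS(=O)(=O)c1ccc(F)cc1` has not been measured. It differs from compound 3 in one place: (4-methylpiperazin-1-yl)methyl in place of hydrogen on a saturated chain carbon bound to an amide-type nitrogen. Read one bond further out, the methylcarbamoyl of compound 3 becomes a (2-(4-methylpiperazin-1-yl)ethyl)carbamoyl. Among the measured compounds shown here, the one measured step that bears on this is the removal of a (pyrrolidin-1-yl)methyl from the same chain carbon, a 2.8-fold higher number from compound 1 to compound 3 (0.45 log units; beyond the scatter), a modest rise in number; its reverse suggests a modest fall. Because a 2.8-fold higher number from compound 1 to compound 3 (0.45 log units; beyond the scatter) went beyond the scatter, compound 4 is expected to give about 350 nM, between 150 nM and 900 nM. The expected step is a 2.5-fold lower number from compound 3 to compound 4 (0.40 log units; beyond the scatter).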

Compound 4, half-maximal inhibitory concentration: 540 nM
Compound 4: the middle estimate sits 1.5-fold (0.19 log units) below what was measured; the measured number falls inside the stated range.
By their numbers in this assay, from the lowest: compounds 1, 4, 3 and 2 (each within the scatter of the next, the first and the last beyond it).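

In this assay the added (4-methylpiperazin-1-yl)methyl on the saturated chain carbon bound to an amide-type nitrogen gives a 1.6-fold lower number from compound 3 to compound 4 (0.21 log units; within the scatter) and so stays within the scatter, whereas the (pyrrolidin-1-yl)methyl at the same carbon had gone beyond it. Exchanging the chain end itself, 4-methylpiperazin-1-yl in place of pyrrolidin-1-yl, gives a 1.7-fold higher number from compound 1 to compound 4 (0.24 log units; within the scatter) and does not tell the two rings apart. Set against the cyclopropyl on a nitrogen on an aromatic ring, the (2-(4-methylpiperazin-1-yl)ethyl)carbamoyl gives a 2.9-fold lower number from compound 2 to compound 4 (0.46 log units; beyond the scatter) and clears the scatter, which the methylcarbamoyl of compound 3 did not.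

Going by these compounds, how a morpholin-4-yl or dimethylamino chain end, or a propyl chain in place of the ethyl, would read remains open. Nothing shown here offers any measured explanation for these numbers.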